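The compounds below may be only part of what the source reports. "The series", "measured", "known", "first", "only" and "open" are said of these compounds alone.

In a functional assay on the whole organism with Mus musculus as the target (a lower number here means that less compound is needed, a higher number that more compound is needed for the effect), three compounds sharing one core have been measured. Compound 1 (`CC[C@@H](C(=O)Nc1ccccc1)N1CCCC1=O`) gives 560 umol/kg, compound 2 (`CC[C@@H](C(=O)NC)N1CCCC1=O`) gives 1800 umol/kg and compound 3 (`CC[C@@H](C(=O)N(C)O)N1CCCC1=O`) gives 1000 umol/kg on this scale. Compound 2 thus stands at the upper end of these numbers, within the scatter of compound 3 and clearly apart from compound 1.

Compound 4 (`CC[C@@H](C(=N)N)N1CCCC1=O`) alters compound 2 at the methylcarbamoyl group itself: a group of 3 heavy atoms (1 carbon, 2 nitrogen; no ring) in place of a group of 4 heavy atoms (2 carbon, 1 nitrogen, 1 oxygen; no ring), on a saturated chain carbon bound to an amide-type nitrogen in a ring and a saturated chain carbon. The exchange lies on a saturated chain carbon bound to an amide-type nitrogen in a ring and a saturated chain carbon.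

Among the compounds with values here, two measured steps bear on this group, though neither replaces it whole. With methyl in place of phenyl on an amide-type nitrogen, the data show a 3.2-fold higher number from compound 1 to compound 2 (0.51 log units; beyond the scatter), a modest step. With hydroxy in place of hydrogen on an amide-type nitrogen, they show a 1.8-fold lower number from compound 2 to compound 3 (0.26 log units; within the scatter), a step that stays within the scatter. Within the data shown here, no measured compound shows the effect of exchanging the whole group, so the direction remains open and the uncertainty is wide.

A small shift in this assay is expected, with the estimate being a 1.2-fold lower number from compound 2 to compound 4 (0.08 log units; within the scatter) and thus none beyond the scatter. For compound 4 the estimated value is 1500 umol/kg, with an expected range from 550 umol/kg to 4500 umol/kg in this assay.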

Compound 4, dose for half-maximal effect: 1000 umol/kg
The estimate for compound 4 lay 1.5-fold (0.18 log units) above the measured number; measured number inside the range.
By their numbers in this assay, from the lowest: compounds 1, 3, 4 and 2 (each within the scatter of the next, the first and the last beyond it).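

In this assay, replacing the whole methylcarbamoyl group gives a 1.8-fold lower number from compound 2 to compound 4 (0.26 log units; within the scatter), so this saturated chain carbon accepts a group of 3 heavy atoms with 2 hydrogen-bond donors in place of the methylcarbamoyl group without a change beyond the scatter. The earlier compounds shown here altered only what sits on the amide-type nitrogen and kept the rest of the methylcarbamoyl group, whereas compound 4 shows that this group as a whole is not required for a number in this range, at least for this one replacement. No measured evidence offered here accounts for this outcome, and the result gives only the size of the step.

The compounds shown leave open whether other replacements at this place, such as a nitrile, a carboxylic acid or an aminomethyl group, would also stay within the scatter of compound 2 or would move the number further. They also leave open whether a phenyl on the new group, the substituent carried by compound 1, would bring a step like a 3.2-fold higher number from compound 1 to compound 2 (0.51 log units; beyond the scatter) in the reverse direction.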